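The compounds below may be only part of what the source reports. "The series", "measured", "known", "first", "only" and "open" are said of these compounds alone.

Measured compounds:
Compound 1 `CC(=N)NCCC(O)c1cc(Cl)ccc1N` gives 49.1% in an assay for inhibition of Nitric oxide synthase, inducible (Homo sapiens), with a stated time of 30 min, tested at 1 mM; on this read-out lower numbers stand for less inhibition and higher numbers for more inhibition at the one concentration tested (going by the name of the read-out).
Compound 2 `COc1ccc(N)c(C(O)CCNC(C)=N)c1` gives 57.4% in this assay.
Compound 3 `CC(=N)NCCC(=O)c1cc(Cl)ccc1N` gives 99.1% in this assay.

Compound 3 stands highest of the three; compound 2 is the nearest to it, and the gap to both compound 2 and compound 1 lies beyond the scatter. The difference between the core of compound 1 and the core of compound 3 is not broken down here. Compound 1 and compound 2 differ in one place, (methoxy in place of chloro on an aromatic carbon), and that change gave a number 8.3 percentage points higher from compound 1 to compound 2 (within the scatter).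

Compound 4 `COc1ccc(N)c(C(=O)CCNC(C)=N)c1` has not yet been measured in this assay. For the measured compounds named here, it differs from compound 3 by methoxy in place of chloro on an aromatic carbon, the same change, at the same place, as the one from compound 1 to compound 2. Since that earlier change stayed within the scatter, and since compound 3 already gives 99.1%, a step of about a number 3.1 percentage points lower from compound 3 to compound 4 (within the scatter) is expected from compound 3 to compound 4, with little room for an upward move. Compound 4 is therefore estimated at 96%, expected between 86% and 100%.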

Compound 4, a percentage reported as inhibition, at one concentration (the size of the read-out at that concentration, not a potency): 97.6%
Estimate against measurement, compound 4: 1.6 percentage points below, and the stated range covers the measured number.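

Methoxy in place of chloro on an aromatic carbon gave a number 1.5 percentage points lower from compound 3 to compound 4 (within the scatter) in this assay. Set beside the earlier step on the other core, the change reads alike on both: the same change on two cores in this assay, a number 8.3 percentage points higher (within the scatter) from compound 1 to compound 2 and a number 1.5 percentage points lower (within the scatter) from compound 3 to compound 4, 9.8 percentage points apart, within the scatter of two such steps. This shows that, in these two pairs, swapping chloro for methoxy left the read-out within the scatter, whichever core carried it, but it does not show that the two groups are interchangeable, as each core rests on a single pair, the read-out is taken at one concentration and is no potency, and a real difference smaller than the scatter would pass unseen.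

The compounds shown leave open whether the same holds for other groups on that aromatic carbon, such as fluoro, bromo or trifluoromethyl. They also leave open how a longer chain, or a dimethylamino group in place of the amino group, would bear on the read-out on either core.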